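This account rests on a few compounds, and the source may have more. Where it says the series, first, only, none or still open, it means among the compounds named here.

Compound 2 `CCOC(=O)c1c(-c2cc3ccccc3oc2=O)nn(-c2ccccc2)c1C(=O)OCC` is a close relative of compound 1 `CCOC(=O)c1c(-c2c(Cl)c3ccccc3oc2=O)nn(-c2ccccc2)c1C(=O)OCC`. In a functional assay on A549 cells (Homo sapiens) for cytotoxicity, read by MTT assay, with a stated time of 48 h (a higher number here means a weaker inhibitor, a lower number a stronger inhibitor), compound 1 gives 34000 nM, while compound 2 gives 100000 nM, the higher of the two numbers. Within the data shown here, the only measured step, a 2.9-fold higher number from compound 1 to compound 2 (0.47 log units; beyond the scatter), concerns the chloro group and not the phenyl ring. Compound 3 `CCOC(=O)c1c(-c2cc3ccccc3oc2=O)nn(-c2ccc(OC)cc2)c1C(=O)OCC` carries methoxy in place of hydrogen on an aromatic carbon. Among the measured compounds shown here, no measured step involves a change of this kind, so nothing here supports expecting a shift beyond the scatter. Compound 3 is therefore expected to give about 100000 nM in this assay, between 40000 nM and 250000 nM. This expectation amounts to no change at the digits printed from compound 2 to compound 3 (within the scatter).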

Compound 3, half-maximal inhibitory concentration: 86000 nM
Beside the measured number, compound 3's estimate is 1.2-fold (0.07 log units) above it; measured number inside the range.
By their numbers in this assay, from the lowest: compound 1; then compounds 3 and 2 (each within the scatter of the next).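

Going from phenyl to 4-methoxyphenyl is the first measured change on this ring, and in this assay it gives a 1.2-fold lower number from compound 2 to compound 3 (0.07 log units; within the scatter). At this place, para to a large group, adding methoxy therefore does not shift the number beyond the scatter, unlike the chloro step, a 2.9-fold higher number from compound 1 to compound 2 (0.47 log units; beyond the scatter). Nothing measured here bears on why this is so. Still open, on these data alone, is whether an amine or a carboxylic acid at the same place would also stay within the scatter. Also open, as far as these compounds go, is whether methoxy would do so on compound 1, which carries the chloro group.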